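This account rests on a few compounds, and the source may have more. Where it says the series, first, only, none or still open, it means among the compounds named here.

Measured compounds:
Compound 1, `CN(C(=O)c1ccc(F)cc1)c1ccc2[nH]c(-c3n[nH]c4ccccc34)cc2n1`, gives 9650 nM.
Compound 2, `CN(c1ccc2[nH]c(-c3n[nH]c4ccccc34)cc2n1)S(=O)(=O)c1ccccc1`, gives 14000 nM.

Both numbers come from a functional assay on A549 cells (Homo sapiens) for antiproliferative activity, read by MTT assay, with a stated time of 72 h; on this read-out lower numbers stand for stronger inhibition and higher numbers for weaker inhibition. Compound 2 stands at the highest of the two numbers, and its nearest neighbour is compound 1. Among the measured compounds shown here, the only measured step, a 1.5-fold higher number from compound 1 to compound 2 (0.16 log units; within the scatter), goes with phenylsulfonyl in place of (4-fluorophenyl)carbonyl on a nitrogen on an aromatic ring and stays within the scatter.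

Compound 3, `Cc1ccc(S(=O)(=O)N(C)c2ccc3[nH]c(-c4n[nH]c5ccccc45)cc3n2)cc1`, differs from compound 2 by methyl in place of hydrogen on an aromatic carbon, which read one bond further out is phenylsulfonyl to (4-methylphenyl)sulfonyl. For the measured compounds named here, no measured step bears directly on this change: the single step available concerns a different part of the molecule and was itself within the scatter. On this basis no step beyond the scatter is expected in this assay, in either direction, for compound 3, and the step from compound 2 to compound 3 is estimated as no change at the digits printed from compound 2 to compound 3 (within the scatter). Compound 3 is therefore expected to give about 14000 nM, within a range of 6000 nM to 33000 nM.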

Compound 3, half-maximal inhibitory concentration: 27100 nM
The estimate for compound 3 lay 1.9-fold (0.29 log units) below the measured number; low and high end bracket the measured number.
By their numbers in this assay, from the lowest: compounds 1, 2 and 3 (each within the scatter of the next, the first and the last beyond it).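

In this assay, among the compounds shown here, methyl in place of hydrogen on the aromatic carbon para to a large group, which turns phenylsulfonyl into (4-methylphenyl)sulfonyl, gives a step that does not separate the two compounds (a 1.9-fold higher number from compound 2 to compound 3 (0.29 log units; within the scatter)), so this is the first reading at this position of the ring and it shows a methyl tolerated there within the scatter. For the compounds shown here, the comparison with the carbonyl compound goes further: (4-methylphenyl)sulfonyl in place of (4-fluorophenyl)carbonyl on the nitrogen gives the only step in the set beyond the scatter, and a modest one (a 2.8-fold higher number from compound 1 to compound 3 (0.45 log units; beyond the scatter)), although each of the two smaller steps leading there stays within the scatter. Nothing measured accounts for this small drift in the numbers, and no information on its origin is at hand.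

The compounds shown leave open whether the sulfonyl link or the group on the ring carries that step, which a (4-fluorophenyl)sulfonyl or a (4-methylphenyl)carbonyl group on the same nitrogen would help to separate. They also leave open how a methoxy group, an amine or a carboxylic acid would read at the position now holding methyl, and whether the numbers can be brought down at all from this range.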